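Second Trifluoromethyl Group and Macrophage Cytotoxicity

The source may hold more compounds than are shown below. What is called first, only, known or untested is meant among the compounds shown, and "the series" means these compounds.

Compound 1 `O=C(Nc1ccc(C(F)(F)F)cc1)c1cc(Cl)ccc1O` gives 2800 nM in an ADME assay on cells (Macrophage, Mus musculus) for cytotoxicity, read by resazurin assay, with a stated time of 3 days; a lower number here means a stronger inhibitor, a higher number a weaker inhibitor. Compound 2 `O=C(Nc1ccc(C(F)(F)F)c(C(F)(F)F)c1)c1cc(Cl)ccc1O` carries one more group, (trifluoromethyl in place of hydrogen on an aromatic carbon), and in this assay compound 2 gives 4900 nM; the step is a 1.8-fold higher number from compound 1 to compound 2 (0.24 log units; within the scatter). Compound 3 `Cc1c(NC(=O)c2cc(Cl)ccc2O)cccc1C(F)(F)F` rests on a different core; the difference between the cores of compound 1 and compound 3 is not broken down here. In this assay compound 3 gives 8000 nM. Compound 4 `Cc1c(NC(=O)c2cc(Cl)ccc2O)cc(C(F)(F)F)cc1C(F)(F)F` has not been measured yet; it differs from compound 3 by trifluoromethyl in place of hydrogen on an aromatic carbon. Going by the values given here, this is the same kind of change as the one leading to compound 2, but not the same change: there the new group sits ortho to a trifluoromethyl group and meta to a large group, here it sits meta to a large group, meta to a trifluoromethyl group and para to a methyl group. Because the earlier step of a 1.8-fold higher number from compound 1 to compound 2 (0.24 log units; within the scatter) stayed within the usual scatter, only a small shift is expected for compound 4, namely a 1.8-fold higher number from compound 3 to compound 4 (0.24 log units; within the scatter). Compound 4 is therefore estimated to give 14000 nM in this assay, most likely between 6000 nM and 35000 nM.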

Compound 4, half-maximal inhibitory concentration: 3200 nM
Beside the measured number, compound 4's estimate is 4.4-fold (0.64 log units) above it; the measured number lies below the stated range.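

In this assay a second trifluoromethyl group on the core of compound 3 gives a 2.5-fold lower number from compound 3 to compound 4 (0.40 log units; beyond the scatter) and so does not repeat the step seen on the core of compound 1, as the two steps differ by more than scatter alone would explain: the same change on two cores in this assay, a 1.8-fold higher number (0.24 log units; within the scatter) from compound 1 to compound 2 and a 2.5-fold lower number (0.40 log units; beyond the scatter) from compound 3 to compound 4, 4.4-fold (0.64 log units) apart, beyond the scatter of two such steps. This shows that, for these two cores, the size and direction of the step on one core did not carry over to the other. It does not show what lies behind the difference, as the new group sits in a different place on each core, so the effects of core and position cannot be separated, and two steps give no rule for any further core.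

The compounds shown leave open whether a trifluoromethyl group in the same place on both cores would give matching steps, and what part the methyl group of compound 3 and compound 4 plays. They also leave open how a nitrile or an amine in the new group's place would behave in this assay on either core.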